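From piperazin-1-yl to pyridin-4-yl on a shared core

The source may report more compounds than this note shows. Statements on the series, on what has been measured and on what is new or still open speak of the compounds shown alone.

Within the data shown here, in a physicochemical assay for solubility, read by HPLC, using the shake flask method, measured as kinetic solubility, with a stated time of 20 h, at pH 6.5, tested at 200 uM (a higher number here means a more soluble compound, a lower number a less soluble compound), compound 1 `CS(=O)(=O)c1cccc(-c2ccc3nccc(N4CCNCC4)c3n2)c1` gives 165000 nM and this is the only exact number so far. Compound 2 `O=S(=O)(NCCO)c1cccc(-c2ccc3nccc(-c4ccc(OC(F)(F)F)cc4)c3n2)c1` reads < 5000 nM in this assay and that reading is a limit of the assay, not a number. Compound 3 `CS(=O)(=O)c1cccc(-c2ccc3nccc(-c4ccncc4)c3n2)c1` has pyridin-4-yl in place of piperazin-1-yl on an aromatic carbon of the core of compound 1, opposite the ring nitrogen. Counted in full, the change reads pyridin-4-yl in place of piperazin-1-yl on an aromatic carbon and nothing else differs. Among the measured compounds shown here, no measured pair shows this change alone, so the expected size of the step is a judgement. Compound 1 stands high at 165000 nM and so has plenty of room to fall. A drop beyond the usual scatter is expected in this assay with an 11-fold lower number from compound 1 to compound 3 (1.04 log units; beyond the scatter) as the estimate. Compound 3 is expected at 15000 nM with 5000 nM to 60000 nM as the estimated range.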

Compound 3, solubility: < 5000 nM
Compound 3: a limit, no number (the forecaster's own chance of this, stated with the estimate: 30%); middle value at least 3.0-fold (0.47 log units) from the limit.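

Among these compounds, on this aromatic carbon of the shared core, opposite the ring nitrogen, the change from piperazin-1-yl to pyridin-4-yl is the first single change that can be read in this assay, and it gives an at least 33-fold lower number from compound 1 to compound 3 (1.51 log units; beyond the scatter). Both groups are six-membered rings with the same count of heavy atoms, so at this position keeping the ring size and the heavy-atom count does not keep the reading. The reading for compound 3 is a limit of the assay and not a number, so the step gives only a minimum size: the limit of < 5000 nM in this assay, at which 2 of the 3 values shown sit.

As far as these compounds go, how far compound 3 lies past that limit remains open. Also open, from the compounds shown here alone, is whether a morpholine ring or an open-chain amine on this carbon would read closer to compound 1 or to compound 3.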